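The compounds below may be only part of what the source reports. "The series", "measured", "known", "first", "only" and "open" are said of these compounds alone.

Compound 1 `O=C(Nc1ccc(F)c(-c2nc3ncc(-c4cc(F)ccc4F)cc3[nH]2)c1)N1CCCC1`: in an ADME assay on HepG2 cells (Homo sapiens) for cytotoxicity, read by resazurin assay, with a stated time of 48 h (a lower number here means that less compound is needed, a higher number that more compound is needed for the effect), compound 1 gives > 50000 nM, a limit of the assay.
Compound 2 `O=C(Nc1ccc(F)c(-c2nc3ncc(-c4ccc(F)cc4F)cc3[nH]2)c1)N1CCCC1`: in this assay compound 2 gives 32400 nM.
Compound 3 `O=C(Nc1ccc(F)c(-c2nc3ncc(-c4cncc(F)c4)cc3[nH]2)c1)N1CCCC1`: in this assay compound 3 gives > 50000 nM, a limit of the assay.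

Compound 3 thus stands at the limit of > 50000 nM in this assay, at which 2 of the 3 values shown sit, so only a limit is known for it. Compound 4 `O=C(Nc1ccc(F)c(-c2nc3ncc(-c4ccc(F)cc4)cc3[nH]2)c1)N1CCCC1` differs from it by 4-fluorophenyl in place of 5-fluoropyridin-3-yl on an aromatic carbon. Going by the values given here, two measured steps touch compound 3: a step that the two limits leave unreadable from compound 1 to compound 3, and an at least 1.5-fold higher number from compound 2 to compound 3 (0.18 log units; that floor lies within the scatter). Neither reads beyond the scatter, so the change to compound 4 is expected to bring no step beyond the scatter, at most a drift back toward the value of compound 2. Compound 4 is therefore estimated at 50000 nM, in the range 25000 nM to 100000 nM, which would mean an expected a number no higher from compound 3 to compound 4 (the limit leaves the size open).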

Compound 4, half-maximal effective concentration: > 50000 nM
Compound 4 gave a limit, no number; the forecaster's own chance of this, stated with the estimate: 60%; the middle value lies on the limit itself.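

In this assay, replacing 5-fluoropyridin-3-yl with 4-fluorophenyl on this aromatic carbon leaves compound 4 at a limit of the assay, like compound 3, and the steps among compound 1, compound 3 and compound 4 cannot be read. Going by these compounds alone, removing one fluoro gives an at least 1.5-fold higher number from compound 2 to compound 4 (0.18 log units; that floor lies within the scatter), so even the smallest change from the only compound with a number shows no step beyond the scatter. Most values at this position now sit at one limit: the limit of > 50000 nM in this assay, at which 3 of the 4 values shown sit.

From the compounds shown here alone, how far compound 1, compound 3 and compound 4 lie past that limit remains open. Also open, going by these compounds, is what an amine or a carboxylic acid on this carbon would give.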